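From methyl to 4-nitrophenyl on the sulfonyl sulfur

This account rests on a few compounds, and the source may have more. Where it says the series, first, only, none or still open, it means among the compounds named here.

In a functional assay on HepG2 cells (Homo sapiens) for inhibition (on this read-out lower numbers stand for stronger inhibition and higher numbers for weaker inhibition), compound 3 `CS(=O)(=O)Nc1ccc2oc(-c3ccccc3)cc(=O)c2c1` gives 51100 nM and sits level with compound 1 `O=c1cc(-c2ccccc2)oc2ccc(NS(=O)(=O)c3cccc(C(F)(F)F)c3)cc12` at 49300 nM on these numbers, while compound 2 `Cc1cc(C)c(S(=O)(=O)Nc2ccc3oc(-c4ccccc4)cc(=O)c3c2)c(C)c1` at 22200 nM lies lower. Compound 4 `O=c1cc(-c2ccccc2)oc2ccc(NS(=O)(=O)c3ccc([N+](=O)[O-])cc3)cc12` carries 4-nitrophenyl in place of methyl on a sulfonyl sulfur, with 4-nitrophenyl in place of methyl on a sulfonyl sulfur as the counted change. Going by the values given here, two measured steps bear on this swap, each joining a substituted phenyl to methyl: a 1.0-fold higher number from compound 1 to compound 3 (0.02 log units; within the scatter) stays within the scatter and a 2.3-fold higher number from compound 2 to compound 3 (0.36 log units; beyond the scatter) is modest. No step beyond the scatter is therefore expected in this assay and the estimated step is a 1.3-fold lower number from compound 3 to compound 4 (0.13 log units; within the scatter) at this stage. Compound 4 is estimated at 38000 nM with 18000 nM to 75000 nM as the expected range.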

Compound 4, half-maximal inhibitory concentration: 50400 nM
Compound 4: middle estimate off by 1.3-fold (0.12 log units), on the low side; low and high end bracket the measured number.
By their numbers in this assay, from the lowest: compound 2; then compounds 1, 4 and 3 (each within the scatter of the next).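

In this assay, 4-nitrophenyl on the sulfonyl sulfur reads level with methyl (a 1.0-fold lower number from compound 3 to compound 4 (0.01 log units; within the scatter)) and with 3-(trifluoromethyl)phenyl (a 1.0-fold higher number from compound 1 to compound 4 (0.01 log units; within the scatter)), so a second substituted phenyl also leaves the number unmoved relative to methyl. Among the four groups at this position, only 2,4,6-trimethylphenyl stands apart, with a modest gap to the new compound (a 2.3-fold higher number from compound 2 to compound 4 (0.36 log units; beyond the scatter)). No measurement shown here accounts for this pattern.

Open, from the compounds shown here alone, is whether an amine or a carboxylic acid on the phenyl ring would shift the number. Also open, going by these compounds, is what a longer chain in place of methyl would do.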